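A few compounds are considered here, and "the series" means these few. Any claim that something is new, unique, unknown or untested is made for them only; others in the source may bear on it.

Measured in a functional assay on MDA-MB-231 cells (Homo sapiens) for cytotoxicity, read by MTT assay, with a stated time of 72 h; a higher number here means a weaker inhibitor, a lower number a stronger inhibitor:
- compound 1 `Cc1cc(/C=C/c2ccc(O)cc2)[nH]n1`: 23200 nM
- compound 2 `COc1ccc(/C=C/c2cc(C)n[nH]2)cc1`: 10700 nM

Of these two compounds, compound 1 has the higher number, 23200 nM, which makes it the weaker inhibitor of the pair. Within the data shown here, its only neighbour is compound 2, at 10700 nM.

Compound 3 `Cc1cc(/C=C/c2ccc(O)c(O)c2)[nH]n1` keeps the core of compound 1 and differs from it in one place: hydroxy in place of hydrogen on an aromatic carbon. Among the measured compounds shown here, no measured step makes this same change, so the evidence is thin. For the measured compounds named here, the only measured step is a 2.2-fold lower number from compound 1 to compound 2 (0.34 log units; beyond the scatter), with methyl in place of hydrogen on an oxygen on an aromatic ring. That step is modest and concerns an oxygen rather than an aromatic carbon, so it serves only as a loose guide to size. On that basis, a modest shift towards a lower number is expected in this assay, although a result within the scatter of compound 1 would not be surprising. The expected change is a 1.9-fold lower number from compound 1 to compound 3 (0.29 log units; within the scatter). For compound 3 the estimated value is 12000 nM, with an expected range from 4000 nM to 30000 nM.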

Compound 3, half-maximal inhibitory concentration: 56700 nM
Estimate against measurement, compound 3: 4.7-fold (0.67 log units) below; measured number outside the range, above it.
By their numbers in this assay, from the lowest: compound 2; then compound 1; then compound 3.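

Placing hydroxy in place of hydrogen on an aromatic carbon, ortho to the existing hydroxy group, gives a 2.4-fold higher number from compound 1 to compound 3 (0.39 log units; beyond the scatter) in this assay and so makes compound 3 a weaker inhibitor than compound 1, showing that this ring carbon is sensitive to substitution and that this change moves the number upwards. Among these compounds, the only earlier step concerned the oxygen of that existing hydroxy group, where methyl in place of hydrogen gave a 2.2-fold lower number from compound 1 to compound 2 (0.34 log units; beyond the scatter) and moved the number the other way, so two single changes on the same ring now point in opposite directions, each by a modest amount. Nothing available here measures why hydroxy at this carbon raises the number.

What the compounds shown leave open is whether a methoxy group, a fluorine atom or an amine at the same aromatic carbon would also raise the number, or whether the rise belongs to hydroxy alone. Also open, going by these compounds, is whether the step seen with hydroxy would keep its direction and size on the core of compound 2, where methyl sits on the oxygen.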